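From 3-ethylphenyl to 3,5-dimethylphenyl

The source may hold more compounds than are shown below. What is called first, only, known or untested is meant among the compounds shown, and "the series" means these compounds.

In a functional assay (Homo sapiens) for antiproliferative activity, read by sulforhodamine B assay, with a stated time of 48 h (on this read-out lower numbers stand for stronger inhibition and higher numbers for weaker inhibition), compound 1 (`Cc1cccc(NS(=O)(=O)c2ccc(N3CCNC3=O)cc2)c1`) gives 290 nM and compound 2 (`CCc1cccc(NS(=O)(=O)c2ccc(N3CCNC3=O)cc2)c1`) gives 270 nM on the same shared core. For the measured compounds named here, the two values lie within the usual scatter of each other, so compound 2 stands level with its only measured neighbour. Compound 3 (`Cc1cc(C)cc(NS(=O)(=O)c2ccc(N3CCNC3=O)cc2)c1`) differs from compound 2 in one group, with 3,5-dimethylphenyl in place of 3-ethylphenyl on a sulfonamide nitrogen. Going by the values given here, only one measured step bears on this change (a 1.1-fold lower number from compound 1 to compound 2 (0.03 log units; within the scatter)), and it stayed within the scatter. Among the compounds with values here, no measured compound yet carries the 3,5-dimethylphenyl group, so this evidence is thin. In this assay no shift beyond the scatter is therefore expected, and the estimated step (a 1.1-fold higher number from compound 2 to compound 3 (0.05 log units; within the scatter)) stays small. Compound 3 is expected at 300 nM, with an estimated range from 110 nM to 800 nM for the measurement.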

Compound 3, half-maximal inhibitory concentration: 260 nM
Compound 3: middle estimate off by 1.2-fold (0.06 log units), on the high side; measured number inside the range.
By their numbers in this assay, from the lowest: compounds 3, 2 and 1 (each within the scatter of the next).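

In this assay, rearranging the same eight carbons from one ethyl group into two methyl groups leaves the number level (a 1.0-fold lower number from compound 2 to compound 3 (0.02 log units; within the scatter)). Adding a methyl group in place of hydrogen on an aromatic carbon also leaves it level (a 1.1-fold lower number from compound 1 to compound 3 (0.05 log units; within the scatter)), so among these three compounds, neither the split of the carbons nor the extra methyl group separates the values beyond the scatter. Nothing available here offers an explanation for this level result.

All three compounds carry only small carbon groups on the phenyl ring attached to the sulfonamide nitrogen, so their level values say little about very different groups. A carboxylic acid, an amine or a longer chain such as butyl on that ring could give a similar number or a clearly different one.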